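The source may report more compounds than this note shows. Statements on the series, on what has been measured and on what is new or still open speak of the compounds shown alone.

Working notes on the series. Compound 2 `O=C(O)C1=Cc2cc(C(C3CCCCC3)n3ccnc3)sc2CC1` is the reference point for the next step. In an assay on isolated protein (Oryctolagus cuniculus) for inhibition of Thromboxane-A synthase (Homo sapiens) (on this read-out higher numbers stand for weaker inhibition and lower numbers for stronger inhibition), compound 2 gives > 10000 nM, which is a limit of the assay and not a number. The record on this: the limit of > 10000 nM in this assay, at which 1 of the 2 values shown sits. The measured comparator is compound 1 `O=C(O)C1=Cc2cc(C(c3ccccc3)n3ccnc3)sc2CC1`; in this assay compound 1 gives 114 nM. For the measured compounds named here, the one measured step, an at least 87-fold higher number from compound 1 to compound 2 (1.94 log units; beyond the scatter), runs from a number to the limit.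

The next compound is compound 3 `CC(C)(C)C(c1cc2c(s1)CCC(C(=O)O)=C2)n1ccnc1`. The change from compound 2: tert-butyl in place of cyclohexyl on a saturated chain carbon bound to an aromatic carbon and an aromatic nitrogen. Going by the values given here, no measured step concerns tert-butyl at this position; the only step available, an at least 87-fold higher number from compound 1 to compound 2 (1.94 log units; beyond the scatter), concerns the exchange of phenyl for cyclohexyl, and the cyclohexyl compound sits at the limit. With compound 2 at a limit, the size of any further step cannot be read exactly, in either direction. The expectation is that compound 3 remains near the limit, with an at least 1.2-fold lower number from compound 2 to compound 3 (0.09 log units; that floor lies within the scatter) as the estimated step. For compound 3 the estimated value in this assay is 8000 nM, with a range from 1500 nM to 30000 nM.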

Compound 3, half-maximal inhibitory concentration: > 10000 nM
Compound 3: no number, only a limit; the forecaster's own chance of this, stated with the estimate: 55%; at least 1.2-fold (0.09 log units) between middle value and limit.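

In this assay compound 3 gives > 10000 nM, which is a limit of the assay and not a number. Tert-butyl in place of phenyl on a saturated chain carbon bound to an aromatic carbon and an aromatic nitrogen gives an at least 87-fold higher number from compound 1 to compound 3 (1.94 log units; beyond the scatter), so the large step seen with cyclohexyl is not confined to a group with a six-membered non-aromatic ring of carbon only: a group with no ring and fewer heavy atoms also ends at the limit. Compound 2 and compound 3 cannot be ranked against each other and the step between them cannot be read, as both rest at the same limit: the limit of > 10000 nM in this assay, at which 2 of the 3 values shown sit.

Of the three groups shown at this position, only the phenyl of compound 1 gives a number, so it stays open whether an aromatic ring as such is what separates compound 1 from compound 2 and compound 3, a question that a pyridyl or thienyl group in the same place would address. Also open, on these data alone, is how a much smaller group such as methyl would read here, and how far beyond the limit compound 2 and compound 3 actually lie.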